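The compounds below may be only part of what the source reports. "The series", "measured", "known", "first", "only" and "open" are said of these compounds alone.

Working notes on the phenyl-pyridazinone series in a functional assay on the whole organism with Rattus norvegicus as the target, at a dose of 100 mg/kg; on this read-out lower numbers stand for less inhibition and higher numbers for more inhibition at the one dose given (going by the name of the read-out).

Of the compounds shown here, three carry numbers so far. Compound 1 `O=c1ccc(-c2ccccc2)nn1CCCNC(=S)Nc1ccccc1` gives 12.1%. Compound 2 `CC/N=C(\S)NCCCCCCn1nc(-c2ccccc2)ccc1=O` gives -5.6%, the lowest of the three; the nearest is compound 1, higher by an amount beyond the usual scatter, and the furthest is compound 3 `CC/N=C(/NC#N)NCCCCn1nc(-c2ccccc2)cc(C)c1=O`, which gives 42.5%, also beyond the scatter above compound 2. Within the data shown here, no pair of these differs in one place only, so no single step can be read from them.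

Compound 4 `N#CNC(=N)NCCCCCCn1nc(-c2ccccc2)ccc1=O` is not yet measured. It differs from compound 2 by a group of 5 heavy atoms (2 carbon, 3 nitrogen; no ring) in place of a group of 5 heavy atoms (3 carbon, 1 nitrogen, 1 sulfur; no ring), on an amine nitrogen. A sizeable upward step is expected here, because compound 3, which also bears a nitrile in its side chain, gives 42.5% while compound 2 gives -5.6%; compound 3 differs in chain length and other places as well, so the reading is loose. Compound 4 is estimated at 25% in this assay, within 0% to 50%. The expected step from compound 2 to compound 4 is a number 30.6 percentage points higher from compound 2 to compound 4 (beyond the scatter).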

Compound 4, a percentage reported as inhibition, in the whole organism at one dose (the size of the read-out at that dose, not a potency): 20.5%
For compound 4 the middle estimate is 4.5 percentage points above the measured one; low and high end bracket the measured number.
By their numbers in this assay, from the lowest: compound 2; then compounds 1 and 4 (each within the scatter of the next); then compound 3.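

In this assay, among these compounds, the exchange on the amine nitrogen gives a number 26.1 percentage points higher from compound 2 to compound 4 (beyond the scatter), the first step that can be read at a single place. The end of the side chain therefore matters on this read-out: with the shared core and the saturated chain held constant, the change alone moves the number beyond the scatter, between two groups of 5 heavy atoms that differ in their atoms and in their counted donors and acceptors. Nothing on hand explains why the number moves.

A urea or a plain amine on the same nitrogen would show whether other end groups fall nearer compound 2 or compound 4. On these data alone, it also remains open whether this exchange gives a similar step on a shorter chain.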